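The source may report more compounds than this note shows. Statements on the series, on what has been measured and on what is new or still open speak of the compounds shown alone.

Measured compounds:
compound 1, `O=C(/C=C/c1ccc(Cl)c(Cl)c1)c1ccc(NC(=S)Nc2ccc(Cl)cc2)cc1`: 6.15 umol/kg
compound 2, `Cc1ccc(/C=C/C(=O)c2ccc(NC(=O)Nc3ccc(Cl)cc3)cc2)cc1`: 39.7 umol/kg

In a functional assay on the whole organism (Abdomen, strain Swiss) with Mus musculus as the target, with a stated time of 30 min (on this read-out higher numbers stand for an effect only at larger amounts of compound and lower numbers for an effect already at smaller amounts), compound 1 gives 6.15 umol/kg, the lowest of the two numbers shown. Compound 2 gives 39.7 umol/kg, a higher number, beyond the usual scatter. Among the measured compounds shown here, no step between measured compounds that differ in one place is available here. Compound 3, `O=C(/C=C/c1ccc(Cl)cc1)c1ccc(NC(=S)Nc2ccc(Cl)cc2)cc1`, is not yet measured; it differs from compound 1 by hydrogen in place of chloro on an aromatic carbon. Without a measured step of this kind, a modest rise in number is expected for compound 3, a 1.6-fold higher number from compound 1 to compound 3 (0.21 log units; within the scatter). Compound 3 is therefore estimated at 10 umol/kg, between 4 umol/kg and 25 umol/kg.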

Compound 3, dose for 50% inhibition: 7.59 umol/kg
Beside the measured number, compound 3's estimate is 1.3-fold (0.12 log units) above it, within the range that was stated.
By their numbers in this assay, from the lowest: compounds 1 and 3 (each within the scatter of the next); then compound 2.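

In this assay, among the compounds shown here, the one pair differing in a single place gives a 1.2-fold higher number from compound 1 to compound 3 (0.09 log units; within the scatter), so the change from 3,4-dichlorophenyl to 4-chlorophenyl leaves the read-out within the scatter. On this aromatic carbon, ortho to a chloro group, the chloro is therefore not required for a number of this size on the shared core. No measurement offered here explains this result.

On these data alone, it remains open whether a larger or different group at this place, such as methoxy, an amine or a carboxylic acid, would also leave the number within the scatter. The remaining chloro group of compound 3 has no single-place comparison either, so its contribution is also unresolved.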